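The compounds below may be only part of what the source reports. "The series", "measured", "known", "first", "only" and "open" are said of these compounds alone.

Measured compounds in the series:

- compound 1, `Cc1cc(NC(=O)Nc2ccc(C(C)(C)C)cc2)c2ccccc2n1`: > 25000 nM
- compound 2, `Cc1cc(NC(=O)Nc2cc(F)cc(F)c2)c2ccccc2n1`: > 25000 nM

The two measured compounds share the same urea-linked core and differ only in the substitution of the aryl ring on the far side of the urea. In an ADME assay on HEK293 cells (Homo sapiens) for cytotoxicity, with a stated time of 72 h (a lower number here means that less compound is needed, a higher number that more compound is needed for the effect), compound 1 gives > 25000 nM; this is a limit of the assay and not a number. Compound 2 in this assay likewise gives > 25000 nM, again a limit rather than a measured value. Compound 1 therefore stands at the limit of > 25000 nM in this assay, at which 2 of the 2 values shown sit. Among the compounds with values here, no step between measured compounds can be computed here, and the two values show only that neither compound reaches the read-out inside the tested range.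

Compound 3, `Cc1cc(NC(=O)Nc2ccc(O)cc2)c2ccccc2n1`, has not yet been measured. Against compound 1 the change is hydroxy in place of tert-butyl on an aromatic carbon. Both measured compounds sit at the same limit, so for this assay the step that the limit leaves unreadable from compound 1 to compound 3 is expected to be none beyond the scatter, with a limit the most probable outcome for compound 3 too. Compound 3 is estimated at 30000 nM, range 10000 nM to 100000 nM.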

Compound 3, half-maximal effective concentration: > 25000 nM
Compound 3 gave a limit, no number; the forecaster's own chance of this, stated with the estimate: 80%; the middle value lies beyond the limit too.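

No step can be read between compound 1 and compound 3 in this assay since hydroxy in place of tert-butyl leaves both at a limit of the assay: the limit of > 25000 nM in this assay, at which 3 of the 3 values shown sit. The compounds shown leave open at what concentration any of them would reach the half-maximal effect, and whether this change shifts that concentration at all.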